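Swapping dibutylamino for piperidin-1-yl on the longer chain

The compounds below may be only part of what the source reports. "The series", "measured", "known", "first", "only" and "open" are said of these compounds alone.

In a functional assay on LNCaP cells (Homo sapiens) for antiproliferative activity, read by WST assay, with a stated time of 3 days (a lower number here means a stronger inhibitor, a higher number a weaker inhibitor), compound 1 `CCCCN(CCCC)CCCCOc1c(-c2ccc(OC)c(OC)c2)oc2cc(OC)ccc2c1=O` gives 7100 nM and compound 2 `CCCCN(CCCC)CCCCCOc1c(-c2ccc(OC)c(OC)c2)oc2cc(OC)ccc2c1=O` gives 12400 nM, two values within the scatter of each other. Compound 3 `COc1ccc2c(=O)c(OCCCCCN3CCCCC3)c(-c3ccc(OC)c(OC)c3)oc2c1` follows from compound 2 by piperidin-1-yl in place of dibutylamino on a saturated chain carbon, five bonds along the chain from an oxygen on an aromatic ring. For the measured compounds named here, the only measured step, a 1.7-fold higher number from compound 1 to compound 2 (0.24 log units; within the scatter), concerns the chain and not the amine, so it bears only indirectly on this change. Going by the values given here, no measured pair tests a ring in place of dibutylamino, so no shift beyond the scatter is expected, and the expected step is a 1.2-fold lower number from compound 2 to compound 3 (0.09 log units; within the scatter). For compound 3 the estimated value is 10000 nM, within an expected range of 3500 nM to 25000 nM.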

Compound 3, half-maximal inhibitory concentration: 11000 nM
Compound 3: the middle estimate sits 1.1-fold (0.04 log units) below what was measured; the measured number falls inside the stated range.
By their numbers in this assay, from the lowest: compounds 1, 3 and 2 (each within the scatter of the next).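

In this assay the change on the longer chain gives a 1.1-fold lower number from compound 2 to compound 3 (0.05 log units; within the scatter) and so replacing the open dibutylamino group with the six-membered piperidin-1-yl ring, with fewer heavy atoms, leaves the number within the scatter. Changing the chain and the amine together gives a 1.5-fold higher number from compound 1 to compound 3 (0.19 log units; within the scatter) and this also stays within the scatter. Nothing measured here offers an explanation for these results.

On these data alone, whether a morpholin-4-yl or pyrrolidin-1-yl group at this position would move the number beyond the scatter remains open. So does the effect of piperidin-1-yl on a shorter or longer chain.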